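The source may hold more compounds than are shown below. What is called first, only, known or untested is meant among the compounds shown, and "the series" means these compounds.

In a functional assay on SW1573 cells (Homo sapiens) for antiproliferative activity, read by sulforhodamine B assay, with a stated time of 48 h (a higher number here means a weaker inhibitor of growth, a lower number a stronger inhibitor of growth), compound 1 `CCOC(=O)C#CC(O/C=C/C(=O)OCC)C(C)C` gives 2800 nM and compound 2 `CCCCCC(C#CC(=O)OC)O/C=C/C(=O)OC` gives 1700 nM, two values within the usual scatter of each other. Compound 3 `CC1CCC(C(C)C)C(OC(=O)C#CC(O/C=C/C(=O)OC2CC(C)CCC2C(C)C)C(C)C)C1` reaches only a limit of the assay, > 100000 nM. Compound 4 `CCC(C#CC(=O)OC)O/C=C/C(=O)OC` has hydrogen in place of propyl on a saturated chain carbon of compound 2, three bonds along the chain from an oxygen on an unsaturated carbon and a triple-bonded carbon (hydrogen in place of propyl on a saturated chain carbon, three bonds along the chain from an oxygen on an unsaturated carbon and a triple-bonded carbon). Among the compounds with values here, no measured pair isolates this change. Compound 1, which carries no pentyl chain either, gives 2800 nM, so only a small shift toward weaker growth inhibition is expected in this assay. The expected step of a 1.5-fold higher number from compound 2 to compound 4 (0.17 log units; within the scatter) stays within the scatter. For compound 4 the estimated value is 2500 nM, with an expected range of 900 nM to 7000 nM.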

Compound 4, concentration for 50% growth inhibition: 540 nM
Estimate against measurement, compound 4: 4.6-fold (0.67 log units) above; the whole stated range lies above it.
By their numbers in this assay, from the lowest: compound 4; then compounds 2 and 1 (each within the scatter of the next). At a limit, above all of these: compound 3.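

In this assay, the change from pentyl to ethyl, with hydrogen in place of propyl on a saturated chain carbon, gives a 3.1-fold lower number from compound 2 to compound 4 (0.50 log units; beyond the scatter). Within the data shown here, this is the first pair differing in one place, and it shows that the chain at this position is not neutral: here the shorter chain goes with stronger growth inhibition. Nothing shown gives a reason for this step.

The compounds shown leave open whether a methyl group in place of the ethyl chain would continue this direction. They also leave open how a chain ending in an amine or a carboxylic acid would behave here.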